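Amide Substituent Swap on a Nitrobenzoxadiazole Thioether Series

The compounds below may be only part of what the source reports. "The series", "measured", "known", "first", "only" and "open" are said of these compounds alone.

Three compounds sharing one core have been characterised in an assay on isolated protein for inhibition of glutathione S-transferase P (Homo sapiens), with a stated time of 10 min; on this read-out higher numbers stand for weaker inhibition and lower numbers for stronger inhibition. Compound 1 `O=C(CCC(=O)OCCCCCCSc1ccc([N+](=O)[O-])c2nonc12)Nc1ccccc1` carries a plain phenyl on the amide nitrogen, and in this assay compound 1 gives 10200 nM. Compound 2 `COc1ccc(NC(=O)CCC(=O)OCCCCCCSc2ccc([N+](=O)[O-])c3nonc23)cc1` gives 420 nM, and compound 3 `O=C(CCC(=O)OCCCCCCSc1ccc([N+](=O)[O-])c2nonc12)Nc1ccc(F)c(Cl)c1` gives 9850 nM. Compound 3 therefore stands second highest of the three numbers, close to compound 1 and far from compound 2: the step of a 1.0-fold lower number from compound 1 to compound 3 (0.02 log units; within the scatter) is within the scatter, whereas a 24-fold lower number from compound 1 to compound 2 (1.39 log units; beyond the scatter) and a 23-fold higher number from compound 2 to compound 3 (1.37 log units; beyond the scatter) are both large.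

Compound 4 `CCN(CC)CCCNC(=O)CCC(=O)OCCCCCCSc1ccc([N+](=O)[O-])c2nonc12` differs from compound 3 by 3-(diethylamino)propyl in place of 3-chloro-4-fluorophenyl on an amide-type nitrogen. Among the measured compounds shown here, none of the measured steps exchanges an aromatic group for an open chain on the amide nitrogen, so no step bears directly on this change. The measured steps show only that this position can move the number strongly, as in a 23-fold higher number from compound 2 to compound 3 (1.37 log units; beyond the scatter), or leave it unchanged, as in a 1.0-fold lower number from compound 1 to compound 3 (0.02 log units; within the scatter). For the measured compounds named here, with no closer precedent, compound 4 is expected to sit near the higher numbers of compounds 1 and 3, with a wide range allowing for a sizeable shift in either direction; the step of a 1.6-fold lower number from compound 3 to compound 4 (0.22 log units; within the scatter) is thus an estimate of modest size. For compound 4 the estimate is 6000 nM, from 1000 nM to 35000 nM.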

Compound 4, half-maximal inhibitory concentration: 9550 nM
For compound 4 the middle estimate is 1.6-fold (0.20 log units) below the measured one; the measured number falls inside the stated range.
By their numbers in this assay, from the lowest: compound 2; then compounds 4, 3 and 1 (each within the scatter of the next).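

In this assay, the open-chain 3-(diethylamino)propyl on the amide-type nitrogen does no differently from either aromatic group it can be set against: a 1.0-fold lower number from compound 3 to compound 4 (0.01 log units; within the scatter) and a 1.1-fold lower number from compound 1 to compound 4 (0.03 log units; within the scatter) both leave the number within the scatter, so at this position a ring is not required to give a number at this level. Among the compounds shown here, the large 23-fold higher number from compound 2 to compound 4 (1.36 log units; beyond the scatter) leaves 4-methoxyphenyl as the only one of the four groups with a clearly lower number, and compounds 1 and 3 show that an aromatic ring on this nitrogen does not by itself go with that lower number. Nothing in the available data gives a reason for these results.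

On these data alone, it remains open whether the lower number of compound 2 is tied to the methoxy group itself, which a 4-hydroxyphenyl or 4-ethoxyphenyl on the same nitrogen would test. As far as these compounds go, it is also open whether the diethylamino end of the chain in compound 4 contributes anything, which a plain hexyl chain or a carboxylic acid at that end would address.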